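The source may hold more compounds than are shown below. What is called first, only, known or untested is meant among the compounds shown, and "the series" means these compounds.

Series notes, benzimidazole-linked acid core (structure shown with each compound). In a functional assay on CHO cells for antagonist activity at sphingosine 1-phosphate receptor 2 (Homo sapiens), read by calcium flux (a lower number here means a stronger inhibitor, a higher number a weaker inhibitor), compound 1 `O=C(O)Cn1nc(Cc2nc3cc(Cl)c(OCC(F)F)cc3[nH]2)c2ccccc2c1=O` gives 12 nM. Compound 2 `O=C(O)Cn1nc(Cc2nc3cc(Cl)c(OCC4CC4)cc3[nH]2)c2ccccc2c1=O`, which carries cyclopropyl in place of difluoromethyl on the saturated chain carbon bound to the ring oxygen, gives 8.8 nM in this assay; the step of a 1.4-fold lower number from compound 1 to compound 2 (0.13 log units; within the scatter) sits within the scatter. For the measured compounds named here, compound 2 thus stands at one end of the two numbers so far, with compound 1 as its only neighbour and within the scatter of it.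

Compound 3 `O=C(O)Cn1nc(Cc2nc3cc(Cl)c(OC(F)(F)F)cc3[nH]2)c2ccccc2c1=O` is the next point at the same ring oxygen: trifluoromethyl in place of cyclopropylmethyl on an oxygen on an aromatic ring. Cut one bond further out, the change reads cyclopropylmethoxy to trifluoromethoxy. Going by the values given here, only one measured step bears on this position, the step from compound 1 to compound 2 at the same ring oxygen, and that step stayed within the scatter. No step beyond the scatter in this assay is therefore expected for compound 3, and a 1.4-fold higher number from compound 2 to compound 3 (0.13 log units; within the scatter) is the expected step. Compound 3 is estimated at 12 nM in this assay, with a range of 5 nM to 30 nM.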

Compound 3, half-maximal inhibitory concentration: 31 nM
Compound 3: middle estimate off by 2.6-fold (0.41 log units), on the low side; the measured number lies above the stated range.
By their numbers in this assay, from the lowest: compounds 2 and 1 (each within the scatter of the next); then compound 3.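

In this assay, the ring oxygen is no longer a position where changes stay within the scatter: trifluoromethyl in place of cyclopropylmethyl gives a 3.5-fold higher number from compound 2 to compound 3 (0.55 log units; beyond the scatter), and trifluoromethyl in place of 2,2-difluoroethyl gives a 2.6-fold higher number from compound 1 to compound 3 (0.41 log units; beyond the scatter). Cyclopropylmethyl and trifluoromethyl are both listed with 4 heavy atoms, so the first of these steps comes without a change in that count, and compound 3 is the only one of the three with fluorine on the carbon bound to the ring oxygen. Nothing measured on these compounds accounts for the higher number of compound 3.

In compound 3, fluorine on that carbon and the loss of any further chain carbon arrive together, and the compounds shown do not separate the two. A plain methyl or ethyl on the same oxygen would bear on that question, and a longer chain or an amine at the end of the chain would show how far this position extends beyond the three groups seen here.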